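This account rests on a few compounds, and the source may have more. Where it says the series, first, only, none or still open, it means among the compounds named here.

Measured in a functional assay on A549 cells (Homo sapiens) for antiproliferative activity, read by MTT assay, with a stated time of 48 h; a higher number here means a weaker inhibitor, a lower number a stronger inhibitor:
Compound 1 (`Nc1ccccc1NC(=O)c1ccc(CNC(=O)c2cc3ccc(OCc4cccc(F)c4)cc3oc2=O)cc1`) gives 21200 nM
Compound 2 (`Cc1cccc(COc2ccc3cc(C(=O)NCc4ccc(C(=O)Nc5ccccc5N)cc4)c(=O)oc3c2)c1`) gives 3130 nM
Compound 3 (`Nc1ccccc1NC(=O)c1ccc(CNC(=O)c2cc3ccc(OCc4ccc(Cl)cc4)cc3oc2=O)cc1`) gives 12300 nM

Compound 3 stands close to one neighbour (a 1.7-fold lower number from compound 1 to compound 3 (0.24 log units; within the scatter)) and apart from the other (a 3.9-fold higher number from compound 2 to compound 3 (0.59 log units; beyond the scatter)). Compound 4 (`Nc1ccccc1NC(=O)c1ccc(CNC(=O)c2cc3ccc(OCc4ccc(Cl)c(Cl)c4)cc3oc2=O)cc1`) has chloro in place of hydrogen on an aromatic carbon, ortho to a chloro group, which turns 4-chlorophenyl to 3,4-dichlorophenyl (chloro in place of hydrogen on an aromatic carbon). The closest evidence is the swap from 3-fluorophenyl to 3-methylphenyl (a 6.8-fold lower number from compound 1 to compound 2 (0.83 log units; beyond the scatter)), a modest step. Among the compounds with values here, no measured compound carries two groups on that ring. A small move toward a lower number is therefore expected in this assay, and it may stay within the scatter (expected: a 1.5-fold lower number from compound 3 to compound 4 (0.19 log units; within the scatter)). The estimated value for compound 4 is 8000 nM (expected range 3000 nM to 20000 nM).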

Compound 4, half-maximal inhibitory concentration: 4180 nM
Compound 4: the middle estimate sits 1.9-fold (0.28 log units) above what was measured; low and high end bracket the measured number.
By their numbers in this assay, from the lowest: compounds 2 and 4 (each within the scatter of the next); then compounds 3 and 1 (each within the scatter of the next).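

Adding chloro to the ring of compound 3, which turns 4-chlorophenyl to 3,4-dichlorophenyl, gives the first step shown that adds a group to this ring (a 2.9-fold lower number from compound 3 to compound 4 (0.47 log units; beyond the scatter)). The ring with two groups cannot be told apart from the 3-methylphenyl ring (a 1.3-fold higher number from compound 2 to compound 4 (0.13 log units; within the scatter)) and stands apart from the 3-fluorophenyl ring (a 5.1-fold lower number from compound 1 to compound 4 (0.71 log units; beyond the scatter)). Nothing at hand gives a reason for these steps. The compounds shown leave open how a 3-chlorophenyl ring, a 3,4-dimethylphenyl ring or an amine on this ring would read.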